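The source may hold more compounds than are shown below. What is called first, only, known or untested is meant among the compounds shown, and "the series" means these compounds.

Working notes on the series. Compound 2 `CNC(=O)c1cc(Oc2ccc(Nc3nccc(N4CCCCC4)n3)cc2)ccn1` gives 52.3% in a functional assay on MDA-MB-231 cells (Homo sapiens) for inhibition, read by MTT assay, with a stated time of 72 h, tested at 20 uM; a higher number here means more inhibition at the concentration tested (going by the name of the read-out), a lower number less inhibition. Compound 1 `CNC(=O)c1cc(Oc2ccc(Nc3nccc(N4CCCC4)n3)cc2)ccn1` carries the change pyrrolidin-1-yl in place of piperidin-1-yl on an aromatic carbon and gives 46.6% in this assay; the step between them is a number 5.7 percentage points lower from compound 2 to compound 1 (within the scatter). Compound 3 `c1cc(N2CCCCC2)nc(Nc2ccc(Oc3ncnc4ccsc34)cc2)n1` differs from compound 2 in the core, (a group of 9 heavy atoms (6 carbon, 2 nitrogen, 1 sulfur; one five-membered aromatic ring with 1 hetero atom, one six-membered aromatic ring with 2 hetero atoms) in place of a group of 10 heavy atoms (7 carbon, 2 nitrogen, 1 oxygen; one six-membered aromatic ring with 1 hetero atom), on an oxygen on an aromatic ring). In this assay compound 3 gives 45.7%; the step between them is a number 6.6 percentage points lower from compound 2 to compound 3 (within the scatter). Compound 3 stands lowest of the three numbers, but all three lie within the scatter of one another, so no order can be drawn among them.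

Compound 4 `c1cc(N2CCCC2)nc(Nc2ccc(Oc3ncnc4ccsc34)cc2)n1` is not yet measured. It differs from compound 3 by pyrrolidin-1-yl in place of piperidin-1-yl on an aromatic carbon, the same change that leads from compound 2 to compound 1, here made on the core of compound 3; the place is described in the same words for both pairs. For compound 4, a step of a number 4.7 percentage points lower from compound 3 to compound 4 (within the scatter) is expected in this assay, set beside the earlier a number 5.7 percentage points lower from compound 2 to compound 1 (within the scatter), because the same change gave a number 5.7 percentage points lower from compound 2 to compound 1 (within the scatter) within the scatter. For compound 4 the estimate in this assay is 41%, with a likely range from 28% to 54%.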

Compound 4, a percentage reported as inhibition, at one concentration (the size of the read-out at that concentration, not a potency): 14.3%
The estimate for compound 4 lay 26.7 percentage points above the measured number; measured number below the stated range.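

In this assay the change of pyrrolidin-1-yl in place of piperidin-1-yl gives a number 31.4 percentage points lower from compound 3 to compound 4 (beyond the scatter), so the size of the step does not carry over from one core to the other: the same change on two cores in this assay, a number 5.7 percentage points lower (within the scatter) from compound 2 to compound 1 and a number 31.4 percentage points lower (beyond the scatter) from compound 3 to compound 4, 25.7 percentage points apart, beyond the scatter of two such steps

On these two pairs, the step seen on the core of compound 2 is therefore a poor guide to the step on the core of compound 3, although the direction is the same on both. Two cores do not make a rule, however, and these numbers do not show which part of the core goes with the larger step, or by what mechanism.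

Open, on these data alone, is whether a morpholin-4-yl or a dimethylamino group on the same aromatic carbon would follow compound 3 or compound 4 on the core of compound 3. Also open, as far as these compounds go, is whether the large step would persist across a full concentration series, since each number here comes from a single concentration.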